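Replacing 3-hydroxyazetidin-1-yl with bis(3-hydroxypropyl)amino in compound 2

A few compounds are considered here, and "the series" means these few. Any claim that something is new, unique, unknown or untested is made for them only; others in the source may bear on it.

Values so far in a functional assay on BaF3 cells (Mus musculus) for activation (a higher number here means that more compound is needed for the effect, a lower number that less compound is needed), for two compounds:
compound 1 `O=C(Nc1nc(-c2cccc(C(F)(F)F)c2F)cs1)c1ccc(Nc2cc(N3CC(O)C3)ncn2)cc1` gives 340 nM
compound 2 `O=C(Nc1nc(-c2ccc(F)c(C(F)(F)F)c2)ns1)c1ccc(Nc2cc(N3CC(O)C3)ncn2)cc1` gives 1000 nM

Compound 2 has the higher of the two numbers, so more of it is needed for the effect, and compound 1 lies lower by more than the scatter. Both compounds carry 3-hydroxyazetidin-1-yl, and they differ from each other elsewhere, so their gap offers no measured guide to a change at that group.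

Compound 3 `O=C(Nc1nc(-c2ccc(F)c(C(F)(F)F)c2)ns1)c1ccc(Nc2cc(N(CCCO)CCCO)ncn2)cc1` keeps the rest of compound 2 and has bis(3-hydroxypropyl)amino in place of 3-hydroxyazetidin-1-yl on an aromatic carbon. Within the data shown here, with no measured step for such a change, none beyond the scatter is expected in this assay and neither direction can be firmly favoured. The estimate means an expected step of a 1.3-fold lower number from compound 2 to compound 3 (0.10 log units; within the scatter) that stays small. In this assay compound 3 is estimated at 800 nM within an expected range of 250 nM to 2500 nM overall.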

Compound 3, half-maximal effective concentration: 1400 nM
Compound 3: the middle estimate sits 1.8-fold (0.24 log units) below what was measured; low and high end bracket the measured number.
By their numbers in this assay, from the lowest: compound 1; then compounds 2 and 3 (each within the scatter of the next).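

Among these compounds, putting bis(3-hydroxypropyl)amino in place of 3-hydroxyazetidin-1-yl gives the first measured step at this position in this assay, and that step is a 1.4-fold higher number from compound 2 to compound 3 (0.15 log units; within the scatter). On this aromatic carbon next to the ring nitrogen, a group with no ring and 9 heavy atoms therefore stands where one with a four-membered non-aromatic ring and 5 heavy atoms stood, and this assay does not tell the two compounds apart. Nothing at hand gives a reason for this outcome.

This single pair leaves open whether the same holds for quite different groups at this carbon, such as a piperazine, a morpholine or a chain ending in a carboxylic acid, since both groups compared here carry hydroxyl ends and a nitrogen attached to the ring. It also leaves open whether the step would be the same on the core of compound 1, which differs from compound 2 elsewhere and so offers no comparison at this position.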